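The compounds below may be only part of what the source reports. "The series", "measured", "known", "first", "only" and "open" are said of these compounds alone.

Measured so far in a functional assay on A549 cells (Homo sapiens) for cytotoxicity, read by sulforhodamine B assay, with a stated time of 48 h; on this read-out lower numbers stand for stronger inhibition and higher numbers for weaker inhibition:
compound 1, `CC(=O)OC[C@H]1O[C@@H](n2cc(CN3C(=O)/C(=C\c4ccccc4)c4ccccc43)nn2)[C@H](OC(C)=O)[C@@H](OC(C)=O)[C@@H]1OC(C)=O`, 17900 nM
compound 2, `CC(=O)OC[C@H]1O[C@@H](n2cc(CN3C(=O)/C(=C\c4ccc(C)cc4)c4ccccc43)nn2)[C@H](OC(C)=O)[C@@H](OC(C)=O)[C@@H]1OC(C)=O`, 16500 nM

Compound 2 stands at the lower of the two numbers, but the gap to compound 1 is small: the step of a 1.1-fold lower number from compound 1 to compound 2 (0.04 log units; within the scatter) shows that methyl in place of hydrogen on an aromatic carbon left this assay essentially unchanged. Within the scatter, the two compounds cannot be ordered.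

Compound 3, `COc1ccc(/C=C2\C(=O)N(Cc3cn([C@@H]4O[C@H](COC(C)=O)[C@@H](OC(C)=O)[C@H](OC(C)=O)[C@H]4OC(C)=O)nn3)c3ccccc32)cc1OC`, is not yet measured. It differs from compound 2 by 3,4-dimethoxyphenyl in place of 4-methylphenyl on a double-bonded chain carbon bound to a double-bonded ring carbon. Among the compounds with values here, the only measured step, from compound 1 to compound 2, is the substituent change on the same aromatic ring; it was within the scatter and gives no sign that substitution on that ring moves this assay. Within the data shown here, no step of a methoxy kind has been measured, so there is nothing to set a direction. On these data alone, the expected step is therefore a 1.1-fold lower number from compound 2 to compound 3 (0.04 log units; within the scatter), that is none beyond the scatter, with a wide allowance; the change itself is untested. Compound 3 is estimated at 15000 nM, in the range 6000 nM to 40000 nM.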

Compound 3, half-maximal inhibitory concentration: 23300 nM
Estimate against measurement, compound 3: 1.6-fold (0.19 log units) below; the measured number falls inside the stated range.
By their numbers in this assay, from the lowest: compounds 2, 1 and 3 (each within the scatter of the next).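

In this assay, the change at this position now extends to a group carrying oxygen: 3,4-dimethoxyphenyl in place of 4-methylphenyl (a 1.4-fold higher number from compound 2 to compound 3 (0.15 log units; within the scatter)) and 3,4-dimethoxyphenyl in place of phenyl (a 1.3-fold higher number from compound 1 to compound 3 (0.11 log units; within the scatter)) both stay within the scatter. Within the data shown here, on a double-bonded chain carbon bound to a double-bonded ring carbon, phenyl, 4-methylphenyl and 3,4-dimethoxyphenyl therefore cannot be ordered, so the insensitivity first seen with the methyl step now also holds for two methoxy groups, with no compound in the set going against it. No supporting data bear on this result.

Still open is whether any substituent on this aromatic ring can move the number beyond the scatter, for example a carboxylic acid, an amine or a chlorine atom, since the three groups shown carry none of these. Also open, on these data alone, is how much the shared core contributes, in particular whether free hydroxyl groups in place of the acetate esters on the sugar would shift the read-out in this assay.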